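The source may report more compounds than this note shows. Statements on the series, on what has been measured and on what is new or still open speak of the compounds shown alone.

Working notes on the thiourea series. Compound 1 `S=C(Nc1ccccc1)Nc1ccc2[nH]ccc2c1` in an ADME assay on isolated protein for inhibition of peroxidase (Raphanus sativus), read by fluorescence and Amplex Red, tested at 5 uM (on this read-out higher numbers stand for a weaker effect at the one concentration tested and lower numbers for a stronger effect), gives 81.4%. For the measured compounds named here, compound 2 `CC(=O)c1ccc(NC(=S)Nc2ccc3[nH]ccc3c2)cc1` in this assay gives 66.3%, the lowest of the two numbers so far; the only measured step, a number 15.1 percentage points lower from compound 1 to compound 2 (beyond the scatter), separates it from compound 1.

The next compound, compound 3 `O=C(c1ccccc1)c1ccc(NC(=S)Nc2ccc3[nH]ccc3c2)cc1`, differs from compound 2 in one place: phenyl in place of methyl on a carbonyl carbon. Going by the values given here, no measured step covers this kind of change, since the one step known, a number 15.1 percentage points lower from compound 1 to compound 2 (beyond the scatter), concerns an acetyl entering for hydrogen on an aromatic carbon rather than a phenyl entering for methyl on a carbonyl carbon. That step gives no direct guide to the size or direction of the new one. Among the compounds with values here, with nothing pointing either way, compound 3 is expected to stay near compound 2, with a step of a number 4.3 percentage points lower from compound 2 to compound 3 (within the scatter) that is expected to fall within the scatter, while the range allowed must be wide because no comparable step has been measured. Compound 3 in this assay is therefore estimated at 62%, somewhere between 44% and 80%.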

Compound 3, a percentage reported as activity, at one concentration (the size of the read-out at that concentration, not a potency): 79.1%
Compound 3: the middle estimate sits 17.1 percentage points below what was measured, and the stated range covers the measured number.
By their numbers in this assay, from the lowest: compound 2; then compounds 3 and 1 (each within the scatter of the next).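

In this assay, the carbonyl on the aromatic carbon does not settle the read-out by itself: what sits on that carbonyl carbon also counts, since phenyl in place of methyl gives a number 12.8 percentage points higher from compound 2 to compound 3 (beyond the scatter) and so reverses the gain in effect that acetyl had brought. Acetyl in place of hydrogen on an aromatic carbon gave a number 15.1 percentage points lower from compound 1 to compound 2 (beyond the scatter), whereas benzoyl in the same place gives a number 2.3 percentage points lower from compound 1 to compound 3 (within the scatter), so among the compounds shown the stronger effect belongs to acetyl alone and not to both carbonyl groups. Nothing measured on these compounds speaks to why methyl and phenyl on the carbonyl carbon part in this way.

From the compounds shown here alone, it remains open whether the stronger effect of compound 2 extends to propanoyl or to a longer chain on the carbonyl carbon, or whether it holds for a carboxylic acid or an amide in the place of acetyl. With one read-out at a single concentration and only these three compounds, the series also leaves open how phenyl bearing a methoxy or an amine on the benzoyl ring would compare.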